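Replacing the terminal ring with an open hydroxyethyl chain

A few compounds are considered here, and "the series" means these few. Any claim that something is new, unique, unknown or untested is made for them only; others in the source may bear on it.

Measured compounds:
Compound 1 `CCc1nn(CC)c(C2CCN(C(=O)CN3CN(c4ccccc4)C4(CCN(C(=O)c5ccc(C6CCCCC6)cc5)CC4)C3=O)CC2)c1C` — in an assay on HEK293 cells for displacement of a labelled ligand from NPC1-like intracellular cholesterol transporter 1 (Homo sapiens) (a lower number here means a stronger inhibitor, a higher number a weaker inhibitor), compound 1 gives "not determined" (no result reported).
Compound 2 `O=C(CN1CN(c2ccccc2)C2(CCN(C(=O)c3ccc(C4CCCCC4)cc3)CC2)C1=O)N1CCC(CO)CC1` — 1100 nM in this assay.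
Compound 3 `CC(C)(C)OC(=O)NC1CCN(C(=O)CN2CN(c3ccccc3)C3(CCN(C(=O)c4ccc(C5CCCCC5)cc4)CC3)C2=O)CC1` — 4800 nM in this assay.

Among the two numbers available, compound 2 holds the lower one, and its nearest neighbour is compound 3, which sits a 4.4-fold higher number from compound 2 to compound 3 (0.64 log units; beyond the scatter) away. For the measured compounds named here, that single step, made by placing (tert-butoxycarbonyl)amino where hydroxymethyl stood on the saturated ring carbon, is the only measured comparison and is modest in size but beyond the scatter.

Compound 4 `O=C(CN1CN(c2ccccc2)C2(CCN(C(=O)c3ccc(C4CCCCC4)cc3)CC2)C1=O)NCCO` is the next candidate. Relative to compound 2 the change is (2-hydroxyethyl)amino in place of 4-(hydroxymethyl)piperidin-1-yl on a carbonyl carbon: the ring bearing the hydroxymethyl is removed and a short hydroxylated chain is attached directly to the carbonyl carbon, whose other neighbour is a saturated chain carbon.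

The step from compound 2 to compound 3 bears on this only loosely, as it changed the group on the ring rather than removing the ring. Because that step was a 4.4-fold higher number from compound 2 to compound 3 (0.64 log units; beyond the scatter), a change of this region did register, and a loss of a similar modest size is the expectation here, although a step within the scatter cannot be excluded. Compound 4 is therefore estimated at 1900 nM, within 600 nM to 6000 nM, which corresponds to an expected 1.7-fold higher number from compound 2 to compound 4 (0.24 log units; within the scatter).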

Compound 4, half-maximal inhibitory concentration: 2000 nM
Compound 4: middle estimate off by 1.1-fold (0.02 log units), on the low side; the measured number falls inside the stated range.
By their numbers in this assay, from the lowest: compounds 2 and 4 (each within the scatter of the next); then compound 3.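

Putting (2-hydroxyethyl)amino in place of 4-(hydroxymethyl)piperidin-1-yl on the carbonyl carbon gives a 1.8-fold higher number from compound 2 to compound 4 (0.26 log units; within the scatter), so this assay does not separate these two compounds. The earlier comparison changed only the group carried on the saturated ring, whereas this pair removes the six-membered ring altogether and still leaves a hydroxyl at the end of the substituent. Within this pair, then, the ring is not needed to keep the reading at this level, even though the group shrinks from 8 heavy atoms to 4 and the count of hydrogen-bond donors rises from 1 to 2, and this holds for this one pair alone.

The compounds shown leave open whether the hydroxyl itself counts, which a plain ethylamino group on the same carbonyl carbon would test, and whether a primary amine or a carboxylic acid at the chain end, or a longer 3-hydroxypropyl chain, would read the same way. Nothing available here bears on why the ring can be removed with so little consequence in this assay.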